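The source may report more compounds than this note shows. Statements on the series, on what has been measured and on what is new or still open speak of the compounds shown alone.

The compounds measured so far:

Compound 1, `C=C1CCCC(C)(C)C1(O)CC/C(C)=C/CC[C@]1(C)CC[C@@H]([C@@H](C)C(=O)OC)OO1`: in a functional assay on NCI-H322M cells (Homo sapiens) for inhibition (on this read-out higher numbers stand for weaker inhibition of growth and lower numbers for stronger inhibition of growth), compound 1 gives > 17500 nM, which is a limit of the assay rather than a number.

Compound 2, `C=C1CCC[C@H]2[C@](C)(CC[C@]3(C)CC[C@H]([C@@H](C)C(=O)O)OO3)[C@@H](C)CC[C@]12C`: in this assay compound 2 gives 1910 nM.

Going by the values given here, compound 2 therefore stands as the only compound with an actual number in this assay; the one other value shown is a limit, as the limit of > 17500 nM in this assay, at which 1 of the 2 values shown sits, records. Compound 3, `C=C1CCC[C@H]2[C@](C)(CC[C@]3(C)CC[C@@H]([C@@H](C)C(=O)O)OO3)[C@@H](C)CC[C@]12C`, has not yet been measured. the two compounds have the same atoms and bonds and differ only in configuration as drawn: 1 of 7 stereo elements differ; a stereocentre at a saturated ring carbon is drawn R in compound 2 and S in compound 3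

Among the compounds with values here, no measured pair differs by a change of this kind alone, so no measured step guides the expectation directly. Compound 1 and compound 2 differ in far more than configuration, and their two values say nothing on their own about a single change at a ring stereocentre. With nothing better to go on, the step from compound 2 to compound 3 is expected to be modest, within or only slightly beyond the scatter, leaning toward weaker inhibition of growth: a 1.7-fold higher number from compound 2 to compound 3 (0.22 log units; within the scatter). For compound 3 the estimated value in this assay is 3200 nM, with a range from 800 nM to 12000 nM.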

Compound 3, concentration for 50% growth inhibition: 4190 nM
Compound 3: middle estimate off by 1.3-fold (0.12 log units), on the low side; measured number inside the range.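

In this assay, redrawing a stereocentre at a saturated ring carbon from R to S gives a 2.2-fold higher number from compound 2 to compound 3 (0.34 log units; beyond the scatter), and this is the first step shown that rests on a single change. The position therefore responds to configuration, though only modestly: the S form, compound 3, still gives an actual number of 4190 nM rather than a limit, whereas compound 1 and compound 2 differ in far more than configuration and could say nothing about this position. The gap can be assigned to this one stereocentre, because nothing else separates the two structures: the fact that compounds 2 and 3 differ only in the configuration as drawn

The compounds shown leave open how the other stereo elements bear on growth inhibition, since only this one changes on its own. They also leave open whether the preference for the R form would persist with an amide or a primary alcohol in place of the carboxylic acid, and so whether it belongs to the stereocentre alone or depends on the group carried with it.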